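Moving the Hydroxy Group on the Anilino Ring

A few compounds are considered here, and "the series" means these few. Any claim that something is new, unique, unknown or untested is made for them only; others in the source may bear on it.

Compound 1, `Fc1cccc(-c2nc(Nc3cccc(Cl)c3)c3cc(F)ccc3n2)c1`, gives > 50000 nM in a functional assay on U2OS cells (Homo sapiens) for cytotoxicity, read by MTT assay, with a stated time of 48 h (on this read-out higher numbers stand for weaker inhibition and lower numbers for stronger inhibition), which is a limit of the assay.
Compound 2, `Fc1cccc(-c2nc(Nc3ccc(Br)cc3)c3cc(F)ccc3n2)c1`, gives > 50000 nM in this assay, again a limit.
Compound 3, `Oc1ccc(Nc2nc(-c3cccc(F)c3)nc3ccc(F)cc23)cc1`, gives > 50000 nM in this assay, also a limit.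

Compound 3 therefore stands at the limit, together with every other value shown (the limit of > 50000 nM in this assay, at which 3 of the 3 values shown sit). The steps a step that the two limits leave unreadable from compound 1 to compound 2, a step that the two limits leave unreadable from compound 1 to compound 3 and a step that the two limits leave unreadable from compound 2 to compound 3 cannot be sized, since both ends of each are limits. Compound 4, `Oc1ccccc1Nc1nc(-c2cccc(F)c2)nc2ccc(F)cc12`, differs from compound 3 only in 2-hydroxyphenyl in place of 4-hydroxyphenyl on a nitrogen on an aromatic ring. Among the measured compounds shown here, no measured step bears on this change. Compound 4 is expected to remain at the limit, so the step that the limit leaves unreadable from compound 3 to compound 4 is estimated as none beyond the scatter. Compound 4 is thus estimated at 70000 nM, within 20000 nM to 250000 nM.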

Compound 4, half-maximal inhibitory concentration: 41400 nM
For compound 4 the middle estimate is 1.7-fold (0.23 log units) above the measured one; measured number inside the range.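

Moving the hydroxy group, so that 2-hydroxyphenyl replaces 4-hydroxyphenyl on the nitrogen, gives the only number in this assay that is not a limit (an at least 1.2-fold lower number from compound 3 to compound 4 (0.08 log units; that floor lies within the scatter)). The comparisons with the bromo and chloro rings read alike (an at least 1.2-fold lower number from compound 2 to compound 4 (0.08 log units; that floor lies within the scatter)) and (an at least 1.2-fold lower number from compound 1 to compound 4 (0.08 log units; that floor lies within the scatter)). Each is only a floor inside the scatter, so no real gain is shown, and the steps among the other compounds cannot be read. From the compounds shown here alone, whether 3-hydroxyphenyl, 2-aminophenyl or 2-methoxyphenyl on the same nitrogen would also give a readable number stays open.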